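The compounds below may be only part of what the source reports. "The series", "measured", "known", "first", "only" and "open" are said of these compounds alone.

Within the data shown here, in a functional assay on the whole organism for inhibition, with Rattus norvegicus as the target, read by paw edema, with stated times of 30 min and 3 h, at a dose of 0.28 mmol/kg by the oral route (a lower number here means less inhibition, a higher number more inhibition at the dose given (going by the name of the read-out)), compound 1 `COc1ccc(-n2nc(C(N)=O)nc2-c2cc(OC)c(OC)c(OC)c2)cc1` gives 106% and compound 2 `COc1ccc(-n2nc(C(=O)Nc3ccccc3OC)nc2-c2cc(OC)c(OC)c(OC)c2)cc1` gives 44%, so compound 2 stands lowest of the two numbers known, the only measured step being a number 62 percentage points lower from compound 1 to compound 2 (beyond the scatter). Compound 3 `COc1ccc(-n2nc(C(=O)Nc3ccc(C)cc3)nc2-c2cc(OC)c(OC)c(OC)c2)cc1` differs from compound 2 by 4-methylphenyl in place of 2-methoxyphenyl on an amide-type nitrogen. Among the measured compounds shown here, no measured step exchanges one such group for another on the amide-type nitrogen; the single known step puts 2-methoxyphenyl in place of hydrogen there, so it bears on this change only indirectly. The step is therefore expected to fall within the scatter, no change at the digits printed from compound 2 to compound 3 (within the scatter). Compound 3 is estimated at 44%, within 15% to 70%.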

Compound 3, a percentage reported as inhibition, in the whole organism at one dose (the size of the read-out at that dose, not a potency): 88%
Beside the measured number, compound 3's estimate is 44 percentage points below it; the whole stated range lies below it.
By their numbers in this assay, from the lowest: compound 2; then compound 3; then compound 1.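

In this assay, the choice of aryl group on the amide-type nitrogen proves decisive: 4-methylphenyl in place of 2-methoxyphenyl gives a number 44 percentage points higher from compound 2 to compound 3 (beyond the scatter). Set against hydrogen at that nitrogen, 4-methylphenyl gives a number 18 percentage points lower from compound 1 to compound 3 (beyond the scatter), a smaller step than the one for 2-methoxyphenyl, so the outcome depends on which group is attached, not merely on the presence of one. Nothing measured here explains this difference. The change swaps both the substituent and its place on the ring, so the two remain unseparated. Going by these compounds, whether 4-methoxyphenyl, 2-methylphenyl or plain phenyl would follow either compound remains open.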